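Cytotoxicity of a Fluorobenzylamino Analogue on Vero Cells

This account rests on a few compounds, and the source may have more. Where it says the series, first, only, none or still open, it means among the compounds named here.

Measured so far:
compound 1, `O=c1cc(NCc2ccc3c(c2)OCCO3)sc2c([N+](=O)[O-])cc(C(F)(F)F)cc12`: > 64 ug/mL
compound 2, `O=c1cc(NCC2CCCCC2)sc2c([N+](=O)[O-])cc(C(F)(F)F)cc12`: > 64 ug/mL
compound 3, `CN(Cc1ccccc1)c1cc(=O)c2cc(C(F)(F)F)cc([N+](=O)[O-])c2s1`: > 64 ug/mL

In an ADME assay on Vero cells (Chlorocebus sabaeus) for cytotoxicity, read by MTT assay, with a stated time of 48 h (on this read-out lower numbers stand for stronger inhibition and higher numbers for weaker inhibition), compound 3 gives only a limit, > 64 ug/mL, not a number. Compound 1 likewise gives only a limit, > 64 ug/mL. Compound 2 also gives only a limit, > 64 ug/mL. Compound 4, `O=c1cc(NCc2ccc(F)cc2)sc2c([N+](=O)[O-])cc(C(F)(F)F)cc12`, has not been measured; it differs from compound 3 by (4-fluorobenzyl)amino in place of benzyl(methyl)amino on an aromatic carbon. The steps seen so far are a step that the two limits leave unreadable from compound 1 to compound 2 and a step that the two limits leave unreadable from compound 2 to compound 3, neither readable, since (the limit of > 64 ug/mL in this assay, at which 3 of the 3 values shown sit). Among the measured compounds shown here, no step therefore gives a direction or size. Compound 4 is expected to give 80 ug/mL, in the range 32 ug/mL to 200 ug/mL, most likely again as a limit. The expected step, a step that the limit leaves unreadable from compound 3 to compound 4, is therefore estimated to be none beyond the scatter.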

Compound 4, half-maximal inhibitory concentration: > 64 ug/mL
Compound 4 was reported as a limit; the forecaster's own chance of this, stated with the estimate: 80%; the middle value is on the limit's open side.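

No step from compound 1, compound 2 or compound 3 to compound 4 can be read in this assay because all four compounds give only a limit: the limit of > 64 ug/mL in this assay, at which 4 of the 4 values shown sit.

The compounds shown leave open what concentration harms these cells and whether changing the amino group alters it.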